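The source may report more compounds than this note shows. Statements on the series, on what has been measured and on what is new or still open speak of the compounds shown alone.

Working notes on the series. Three compounds sharing one core have numbers in a functional assay on A549 cells (Homo sapiens) for antiproliferative activity, read by MTT assay, with a stated time of 48 h; a lower number here means a stronger inhibitor, a higher number a weaker inhibitor. Compound 1 `CC(C)=CCC[C@]1(C)/C=C/[C@@H](OC(=O)C=C(C)C)[C@](C)(O)/C=C/C(=O)/C(CN2CCN(C)CC2)=C\C1` gives 940 nM in this assay, the lowest of the three; the nearest is compound 2 `CC(C)=CCC[C@]1(C)/C=C/[C@@H](OC(=O)C=C(C)C)[C@](C)(O)/C=C/C(=O)/C(COC(=O)c2ccc([N+](=O)[O-])cc2)=C\C1`, which in this assay gives 1310 nM, and the furthest is compound 3 `CC(C)=CCC[C@](C)(/C=C/[C@@H](OC(=O)C=C(C)C)[C@](C)(O)/C=C/C(=O)/C=C/N1CCN(C)CC1)CC=O`, which in this assay gives 2660 nM. Compound 3 differs from compound 1 in more than one place, so only its value is noted beside that of compound 1.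

Compound 4 `CC(C)=CCC[C@]1(C)/C=C/[C@@H](OC(=O)C=C(C)C)[C@](C)(O)/C=C/C(=O)/C(C(=O)N2CCCC2)=C\C1` is not yet measured. It differs from compound 1 by (pyrrolidin-1-yl)carbonyl in place of (4-methylpiperazin-1-yl)methyl on a double-bonded ring carbon. Among the compounds with values here, the only single step touching that position is a 1.4-fold higher number from compound 1 to compound 2 (0.14 log units; within the scatter), which fell within the scatter although a large group replaced a small one. Compound 4 keeps a cyclic amine there, now as a (pyrrolidin-1-yl)carbonyl group, and this exchange is expected to move the number little, so the estimated step is a 1.3-fold higher number from compound 1 to compound 4 (0.11 log units; within the scatter), not clearly beyond the scatter. For compound 4 in this assay the estimated value is 1200 nM, with a range from 500 nM to 3000 nM.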

Compound 4, half-maximal inhibitory concentration: 13000 nM
Compound 4: middle estimate off by 11-fold (1.03 log units), on the low side, and the stated range ends below it.
By their numbers in this assay, from the lowest: compounds 1 and 2 (each within the scatter of the next); then compound 3; then compound 4.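

In this assay, this position on the double-bonded ring carbon does not tolerate every group: the exchange for (pyrrolidin-1-yl)carbonyl gives a large step (a 14-fold higher number from compound 1 to compound 4 (1.14 log units; beyond the scatter)), whereas the ((4-nitrophenyl)carbonyl)oxy exchange stays within the scatter (a 1.4-fold higher number from compound 1 to compound 2 (0.14 log units; within the scatter)). Keeping a cyclic amine at this place is therefore not enough to hold the number, and the size of the entering group does not track the size of the step in these two exchanges. Nothing available here accounts for the size of this step.

The compounds shown leave open whether the step goes with the carbonyl or with the five-membered ring, a question that (pyrrolidin-1-yl)methyl or (4-methylpiperazin-1-yl)carbonyl at this carbon would address. As far as these compounds go, how an open-chain dimethylamino methyl group or a carboxylic acid at the same carbon would read also remains open.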